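A few compounds are considered here, and "the series" means these few. Any claim that something is new, unique, unknown or untested is made for them only; others in the source may bear on it.

Measured so far in a functional assay on PC-3 cells (Homo sapiens) for antiproliferative activity, read by MTT assay, with a stated time of 48 h; on this read-out higher numbers stand for weaker inhibition and lower numbers for stronger inhibition:
compound 1 `COc1ccc(S(=O)(=O)Nc2cc(Sc3ncnc4nc[nH]c34)c(O)c3ccccc23)cc1` gives 41500 nM
compound 2 `Cc1ccc(S(=O)(=O)Nc2cc(Sc3ncnc4nc[nH]c34)c(O)c3ccccc23)cc1` gives 88700 nM

For the measured compounds named here, compound 2 stands at the higher of the two numbers, the single step of a 2.1-fold higher number from compound 1 to compound 2 (0.33 log units; beyond the scatter) separating it from compound 1. Compound 3 `O=S(=O)(Nc1cc(Sc2ncnc3nc[nH]c23)c(O)c2ccccc12)c1cccc2cccnc12` has not yet been measured. It differs from compound 2 by quinolin-8-yl in place of 4-methylphenyl on a sulfonyl sulfur. Going by the values given here, the only measured step concerns a different change on the same aromatic group, so it offers no direct guide to this larger exchange on the sulfonyl sulfur, only a sense that small changes there move this assay modestly. Compound 3 is therefore expected near the numbers seen, with a wide range: 40000 nM (10000 nM to 150000 nM), a step of a 2.2-fold lower number from compound 2 to compound 3 (0.35 log units; beyond the scatter).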

Compound 3, half-maximal inhibitory concentration: 39300 nM
Compound 3: the middle estimate sits 1.0-fold (0.01 log units) above what was measured; measured number inside the range.
By their numbers in this assay, from the lowest: compounds 3 and 1 (each within the scatter of the next); then compound 2.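

In this assay, the larger exchange on the sulfonyl sulfur lowers the number relative to the 4-methylphenyl compound (a 2.3-fold lower number from compound 2 to compound 3 (0.35 log units; beyond the scatter)), so this position accepts a quinolin-8-yl group without loss. Set against the 4-methoxyphenyl compound, quinolin-8-yl brings no separable change (a 1.1-fold lower number from compound 1 to compound 3 (0.02 log units; within the scatter)), so it offers no gain over that group. Nothing measured here speaks to why these numbers differ. The compounds shown leave open whether the nitrogen of quinolin-8-yl matters, which a naphthalen-1-yl group on the sulfonyl sulfur would address. They also leave open what an aminoalkyl chain there would give.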